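This account rests on a few compounds, and the source may have more. Where it says the series, first, only, none or still open, it means among the compounds named here.

Measured so far:
compound 1 `N#CC1=C(N)Oc2c(c3nc4ccccc4nc3c3ccccc23)C12C(=O)N(Cc1cnnn1-c1ccc(F)c(Cl)c1)c1ccccc12`; in a functional assay on A549 cells (Homo sapiens) for antiproliferative activity, read by MTT assay, with a stated time of 48 h (a higher number here means a weaker inhibitor, a lower number a stronger inhibitor), compound 1 gives > 50000 nM
compound 2 `COc1ccc(-n2nncc2CN2C(=O)C3(C(C#N)=C(N)Oc4c(N)cc5nc6ccccc6nc5c43)c3ccccc32)cc1`; in this assay compound 2 gives > 50000 nM

The value for compound 1 in this assay is a limit of the assay, not a number. The value for compound 2 in this assay is likewise a limit, not a number. Within the data shown here, compound 2 thus stands at the point where every value shown sits (the limit of > 50000 nM in this assay, at which 2 of the 2 values shown sit); no step between measured compounds can be drawn from this.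

Compound 3 `N#CC1=C(N)Oc2c(N)cc3nc4ccccc4nc3c2C12C(=O)N(Cc1cnnn1-c1ccc([N+](=O)[O-])cc1[N+](=O)[O-])c1ccccc12` differs from compound 2 in one place: 2,4-dinitrophenyl in place of 4-methoxyphenyl on an aromatic nitrogen.

With only limits in hand, there is no basis for expecting a shift in either direction, and the expected step in this assay is a step that the limit leaves unreadable from compound 2 to compound 3, none beyond the scatter. Compound 3 is estimated at 60000 nM, with a range from 20000 nM to 200000 nM, and most probably again only a limit will be reported.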

Compound 3, half-maximal inhibitory concentration: > 50000 nM
Compound 3 gave a limit, no number; the forecaster's own chance of this, stated with the estimate: 80%; the middle value does not contradict the limit.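

Among these compounds, compound 2 and compound 3 both give a limit of the assay, not a number, so no step between them can be read: the limit of > 50000 nM in this assay, at which 3 of the 3 values shown sit.

The compounds shown leave open whether any group on the aromatic nitrogen gives a readable number in this assay at all.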